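This account rests on a few compounds, and the source may have more. Where it says the series, first, only, none or still open, it means among the compounds named here.

Measured so far in a physicochemical assay for lipophilicity, read by NMR; on this read-out lower numbers stand for lower lipophilicity and higher numbers for higher lipophilicity:

compound 1 `CCC(F)CCO` gives 0.75
compound 2 `CC(F)CCO` gives 0.17
compound 3 `CCC(F)(F)CO` gives 0.67

Compound 2 and compound 1 differ in one place, (methyl in place of hydrogen on a saturated chain carbon, two bonds along the chain from a fluorine atom), and this change made a number 0.58 log units higher from compound 2 to compound 1 (beyond the scatter), a step beyond the scatter. Compound 3 and compound 1 lie within the scatter of each other, so no order between them is read from these numbers; the gap from compound 2 up to compound 3 lies beyond the scatter. The difference between the core of compound 2 and the core of compound 3 is not broken down here.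

Compound 4 `CCCC(F)(F)CO` is not yet measured. It differs from compound 3 by methyl in place of hydrogen on a saturated chain carbon, three bonds along the chain from two fluorine atoms. For the measured compounds named here, this is the same kind of change as the one from compound 2 to compound 1, not the same: in the earlier pair the place is two bonds along the chain from a fluorine atom, whereas in the new pair it is three bonds along the chain from two fluorine atoms. The change occurs twice among these compounds, once measured and once pending.

The expectation for compound 4 rests on compound 1, whose step from compound 2 was a number 0.58 log units higher from compound 2 to compound 1 (beyond the scatter); a step of similar size, a number 0.53 log units higher from compound 3 to compound 4 (beyond the scatter), is expected from compound 3 to compound 4 in this assay. For compound 4 the estimate is 1.2, expected to fall between 0.9 and 1.5.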

Compound 4, partition coefficient: 1.25
Compound 4: the middle estimate sits 0.05 log units below what was measured, within the range that was stated.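

In this assay methyl in place of hydrogen on a saturated chain carbon, three bonds along the chain from two fluorine atoms, gave a number 0.58 log units higher from compound 3 to compound 4 (beyond the scatter) and the same kind of change, two bonds along the chain from a fluorine atom, gave a number 0.58 log units higher from compound 2 to compound 1 (beyond the scatter) on the other core, so the two steps are printed at the same size and the change carried over between these two cores on this read-out. This rests on two pairs only, which differ both in the core and in the place of the change; the number of fluorine atoms and the distance to them vary together here, so neither can be read on its own, and no general rule for the series follows. No supporting measurement bears on why the step has this size.

On these data alone, whether the step holds on a core carrying an amine or a carboxylic acid, or on a core with no fluorine atom, stays open. Also open, as far as these compounds go, is how far the pattern runs along a longer chain, beyond the methyl to ethyl difference seen in these two pairs.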